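The source may hold more compounds than are shown below. What is called first, only, known or untested is meant among the compounds shown, and "the series" means these compounds.

Compound 1 `CC(C)(C)c1ccc(C(=O)N2CCC3(CC2)C(=O)N(CC(=O)NCCO)CN3c2ccccc2)cc1` — 1000 nM
Compound 2 `CC(C)(C)OC(=O)N1CCN(C(=O)CN2CN(c3ccccc3)C3(CCN(C(=O)c4ccc(C5CCCCC5)cc4)CC3)C2=O)CC1` — 3500 nM
Compound 3 `CCc1nn(CC)c(C2CCN(C(=O)CN3CN(c4ccccc4)C4(CCN(C(=O)c5ccc(C(C)(C)C)cc5)CC4)C3=O)CC2)c1C` — 2500 nM

All three were tested in an assay on HEK293 cells for displacement of a labelled ligand from NPC1-like intracellular cholesterol transporter 1 (Homo sapiens); on this read-out lower numbers stand for stronger inhibition and higher numbers for weaker inhibition. Compound 1 gives 1000 nM, the lowest of the three numbers and so the strongest inhibitor here; compound 3 with 2500 nM lies nearest, and compound 2 with 3500 nM furthest, both beyond the scatter. Compound 4 `CC(C)(C)c1ccc(C(=O)N2CCC3(CC2)C(=O)N(CC(=O)N2CCNCC2)CN3c2ccccc2)cc1` has not yet been measured. It differs from compound 1 in one place: piperazin-1-yl in place of (2-hydroxyethyl)amino on a carbonyl carbon. For the measured compounds named here, no measured pair shows exactly this change, so there is no direct guide. Compounds 2 and 3 also carry a ring where compound 1 has the (2-hydroxyethyl)amino group and give the higher numbers, but each differs from compound 1 elsewhere too. The step is therefore expected to be modest, a 1.6-fold higher number from compound 1 to compound 4 (0.20 log units; within the scatter), toward a somewhat weaker number. Compound 4 is estimated at 1600 nM, within 500 nM to 5000 nM.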

Compound 4, half-maximal inhibitory concentration: 22000 nM
The estimate for compound 4 lay 14-fold (1.14 log units) below the measured number; the measured number lies above the stated range.
By their numbers in this assay, from the lowest: compound 1; then compounds 3 and 2 (each within the scatter of the next); then compound 4.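

In this assay, putting piperazin-1-yl in place of (2-hydroxyethyl)amino on a carbonyl carbon gives a 22-fold higher number from compound 1 to compound 4 (1.34 log units; beyond the scatter), so inhibition is clearly sensitive to the group at this place. The change swaps an open chain for a six-membered non-aromatic ring with 2 hetero atoms and leaves one hydrogen-bond donor fewer, and this single pair cannot separate those differences. Nothing available here explains the weakening.

On these data alone, it remains open whether the ring or its second nitrogen matters more. Morpholin-4-yl or dimethylamino on the same carbonyl would help separate the two.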